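Pyridinylamino side chain swap on the thiophene sulfonamide

The source may hold more compounds than are shown below. What is called first, only, known or untested is meant among the compounds shown, and "the series" means these compounds.

Measured so far in an assay on isolated protein for inhibition of coagulation factor X (Oryctolagus cuniculus), tested at 1 uM; on this read-out higher numbers stand for more inhibition at the one concentration tested (going by the name of the read-out) and lower numbers for less inhibition:
compound 1 `O=C1[C@@H](NS(=O)(=O)c2ccc(-c3ccon3)s2)CCN1Cc1cc2cc[nH]cc-2n1` gives 49%
compound 2 `O=C1[C@@H](NS(=O)(=O)c2nc3cc(Cl)ccc3[nH]2)CCN1Cc1cc2cc[nH]cc-2n1` gives 21%
compound 3 `O=C1[C@@H](NS(=O)(=O)c2nc3cc(Cl)ccc3[nH]2)CCN1CCNc1ccncc1` gives 29%

Compound 1 stands highest of the three in this assay. The two cores differ by 5-(1,2-oxazol-3-yl)thiophen-2-yl in place of 5-chloro-1H-benzimidazol-2-yl on a sulfonyl sulfur; that difference is tied to a number 28 percentage points lower from compound 1 to compound 2 (beyond the scatter).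

Compound 3 is made from compound 2 by a group of 8 heavy atoms (6 carbon, 2 nitrogen; one six-membered aromatic ring with 1 hetero atom) in place of a group of 9 heavy atoms (7 carbon, 2 nitrogen; one five-membered aromatic ring with 1 hetero atom, one six-membered aromatic ring with 1 hetero atom), on a saturated chain carbon bound to an amide-type nitrogen in a ring. Its step is a number 8 percentage points higher from compound 2 to compound 3 (within the scatter), a change that stays within the scatter.

Compound 4 `O=C1[C@@H](NS(=O)(=O)c2ccc(-c3ccon3)s2)CCN1CCNc1ccncc1` is not yet measured. For the measured compounds named here, it is made from compound 1 by a group of 8 heavy atoms (6 carbon, 2 nitrogen; one six-membered aromatic ring with 1 hetero atom) in place of a group of 9 heavy atoms (7 carbon, 2 nitrogen; one five-membered aromatic ring with 1 hetero atom, one six-membered aromatic ring with 1 hetero atom), on a saturated chain carbon bound to an amide-type nitrogen in a ring, the same change as the one from compound 2 to compound 3, at the same place. Going by the values given here, only one example of this change is at hand, on a different core, so the expectation rests on a single pair.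

For compound 4 in this assay the estimated step is a number 4 percentage points higher from compound 1 to compound 4 (within the scatter), set beside a number 8 percentage points higher from compound 2 to compound 3 (within the scatter) because that step stayed within the scatter. Compound 4 is therefore expected to give about 53%, with a range from 38% to 68%.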

Compound 4, a percentage reported as inhibition, at one concentration (the size of the read-out at that concentration, not a potency): 22%
Beside the measured number, compound 4's estimate is 31 percentage points above it; measured number outside the range, below it.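

In this assay, putting ((pyridin-4-yl)amino)methyl in place of the larger group, on a saturated chain carbon bound to an amide-type nitrogen in a ring, gives a number 27 percentage points lower from compound 1 to compound 4 (beyond the scatter). For the compounds shown here, the change therefore does not carry over as one fixed step from one core to the other: the same change on two cores in this assay, a number 8 percentage points higher (within the scatter) from compound 2 to compound 3 and a number 27 percentage points lower (beyond the scatter) from compound 1 to compound 4, 35 percentage points apart, beyond the scatter of two such steps With only two matched pairs, this shows that the step on one of these cores cannot stand in for the step on the other, but it does not show what in the cores sets the difference, or how the change would behave on any third core.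

Open, as far as these compounds go, is whether a longer chain ending in the same pyridin-4-yl amino unit, or a plain dimethylamino group in its place, would follow the step on the core of compound 1 or the step on the core of compound 2. Also open, from the compounds shown here alone, is how a sulfonyl substituent such as 5-chlorothiophen-2-yl would respond to the same change.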